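A sulfur-linked ring gives way to a methylpiperazine

The source may report more compounds than this note shows. Statements on the series, on what has been measured and on what is new or still open speak of the compounds shown alone.

Compound 3 `Cn1ccnc1SCC(=O)Nc1ccc(-c2nc(-c3ccccc3)c(-c3ccccc3)n2C)cc1` is one of three measured members of a small series that share one core. In a functional assay on MCF7 cells (Homo sapiens) for cytotoxicity, read by MTT assay, with a stated time of 24 h, tested at 6.4 ug/mL (on this read-out higher numbers stand for a stronger effect at the one concentration tested and lower numbers for a weaker effect), compound 3 gives 27.2%, the second highest of the three numbers. Its closest neighbour is compound 2 `Cn1c(-c2ccc(NC(=O)CSc3nc4cc(Cl)ccc4o3)cc2)nc(-c2ccccc2)c1-c1ccccc1`, which gives 27.7%; the step of a number 0.5 percentage points lower from compound 2 to compound 3 (within the scatter) means the two cannot be told apart. The lowest number belongs to compound 1 `Cn1c(-c2ccc(NC(=O)CCl)cc2)nc(-c2ccccc2)c1-c1ccccc1`, which gives 14.2%. Both larger groups raised the read-out over that starting point: a number 13.5 percentage points higher from compound 1 to compound 2 (beyond the scatter) and a number 13 percentage points higher from compound 1 to compound 3 (beyond the scatter).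

Compound 4 `CN1CCN(CC(=O)Nc2ccc(-c3nc(-c4ccccc4)c(-c4ccccc4)n3C)cc2)CC1` has not been measured. It differs from compound 3 in one place: 4-methylpiperazin-1-yl in place of (1-methyl-1H-imidazol-2-yl)sulfanyl on a saturated chain carbon bound to a carbonyl carbon. The two steps from compound 1 show that replacing chloro with a sulfur-linked aromatic ring gave a modest rise, and the step between compound 2 and compound 3 shows that swapping one such ring for another changed nothing beyond the scatter. Going by the values given here, no measured step removes the sulfur altogether and puts a saturated ring in its place, so direct guidance for this change is lacking. The step of a number 5.2 percentage points lower from compound 3 to compound 4 (within the scatter) is therefore expected to be small, most likely within the scatter or a slight fall. For compound 4 the estimated value is 22%, expected to lie between 8% and 38%.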

Compound 4, a percentage reported as activity, at one concentration (the size of the read-out at that concentration, not a potency): 28.6%
Estimate against measurement, compound 4: 6.6 percentage points below, and the stated range covers the measured number.
By their numbers in this assay, from the lowest: compound 1; then compounds 3, 2 and 4 (each within the scatter of the next).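

Until now, both groups that raised the number over chloro held a sulfur and an aromatic ring, so the rise could have depended on either feature. The 4-methylpiperazin-1-yl group holds neither, yet in this assay the rise over chloro remains, with a number 14.4 percentage points higher from compound 1 to compound 4 (beyond the scatter) on the same saturated chain carbon bound to a carbonyl carbon. The comparisons with the sulfur-linked groups, a number 1.4 percentage points higher from compound 3 to compound 4 (within the scatter) and a number 0.9 percentage points higher from compound 2 to compound 4 (within the scatter) for the second, show that these three groups cannot be told apart here, while chloro alone stands apart. No further measurement bears on this result, so it remains a description and not an explanation.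

Still open, as far as these compounds go, is how a small open-chain amine such as dimethylamino, or a ring such as morpholin-4-yl or piperidin-1-yl, would read on the same carbon. The compounds shown also leave open whether a longer chain carrying the 4-methylpiperazin-1-yl group would change the number, and whether compounds 2, 3 and 4 would separate at other concentrations.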